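The source may hold more compounds than are shown below. What is called first, only, known or untested is meant among the compounds shown, and "the series" means these compounds.

Compound 3, with the structure `CN1CCN(c2ccc(Nc3ncc4nc(Nc5ccccc5)n([C@H]5CCN(S(=O)(=O)C6CC6)C5)c4n3)cc2)CC1`, gives 1.6 nM in a functional assay on HCC827 cells (Homo sapiens) for antiproliferative activity, read by MTT assay, with a stated time of 72 h (a higher number here means a weaker inhibitor, a lower number a stronger inhibitor), the lowest number among the three compounds measured. Its companions share the same core and differ only at the amine nitrogen of the five-membered ring: compound 1, `CN1CCN(c2ccc(Nc3ncc4nc(Nc5ccccc5)n([C@@H]5CCNC5)c4n3)cc2)CC1`, gives 65 nM, and compound 2, `CC(=O)N1CC[C@H](n2c(Nc3ccccc3)nc3cnc(Nc4ccc(N5CCN(C)CC5)cc4)nc32)C1`, gives 260 nM. The steps of a 41-fold lower number from compound 1 to compound 3 (1.61 log units; beyond the scatter) and a 160-fold lower number from compound 2 to compound 3 (2.21 log units; beyond the scatter) show how much of the potency of compound 3 rests on the cyclopropylsulfonyl group, while a 4.0-fold higher number from compound 1 to compound 2 (0.60 log units; beyond the scatter) shows that capping the ring nitrogen with acetyl costs something relative to the free amine.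

Compound 4, `CNC(=O)CN1CC[C@H](n2c(Nc3ccccc3)nc3cnc(Nc4ccc(N5CCN(C)CC5)cc4)nc32)C1`, carries the change ((methylcarbamoyl)methyl in place of cyclopropylsulfonyl on an amine nitrogen in a ring). Because of a 160-fold lower number from compound 2 to compound 3 (2.21 log units; beyond the scatter) and a 41-fold lower number from compound 1 to compound 3 (1.61 log units; beyond the scatter), removing the cyclopropylsulfonyl group is expected to give a markedly higher number. The entering group keeps the ring nitrogen as an amine, as in compound 1 with 65 nM, rather than as an amide as in compound 2, so the expected step is a 63-fold higher number from compound 3 to compound 4 (1.80 log units; beyond the scatter), a large loss. The estimate for compound 4 is 100 nM, with a range from 30 nM to 400 nM.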

Compound 4, half-maximal inhibitory concentration: 170 nM
Estimate against measurement, compound 4: 1.7-fold (0.23 log units) below, and the stated range covers the measured number.
By their numbers in this assay, from the lowest: compound 3; then compound 1; then compounds 4 and 2 (each within the scatter of the next).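

In this assay the loss on leaving cyclopropylsulfonyl is not confined to acetyl: (methylcarbamoyl)methyl, which has no ring and brings a hydrogen-bond donor, also fails to hold the potency of compound 3 at this amine nitrogen (a 110-fold higher number from compound 3 to compound 4 (2.03 log units; beyond the scatter)). The entering group and acetyl cannot be told apart here (a 1.5-fold lower number from compound 2 to compound 4 (0.18 log units; within the scatter)), although one keeps the ring nitrogen an amine and the other does not. Keeping it an amine does not match the free pyrrolidin-3-yl either (a 2.6-fold higher number from compound 1 to compound 4 (0.42 log units; beyond the scatter)), so both of these groups cost potency against the free amine, while compound 3 goes the other way.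

A methylsulfonyl or a cyclopropylcarbonyl group on this nitrogen would show whether the gain belongs to the sulfonyl link or to the cyclopropyl ring. Why these groups differ so widely at this position remains open, as nothing measured here bears on it.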